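This account rests on a few compounds, and the source may have more. Where it says the series, first, only, none or still open, it means among the compounds named here.

The two measured compounds share one core, the scaffold carrying a naphthyl substituent on one ring carbon of a five-membered ring. Compound 1 `CC(=O)N1N=C(c2cccc3ccccc23)CC1c1ccccc1` carries an acetyl group on the ring nitrogen and a plain phenyl on the saturated ring carbon; in a functional assay on HEp-2 cells (Homo sapiens) for cytotoxicity, read by sulforhodamine B assay, with a stated time of 48 h (a higher number here means a weaker inhibitor, a lower number a stronger inhibitor), compound 1 gives 11200 nM. Compound 2 `O=CCN1N=C(c2ccc3ccccc3c2)CC1c1ccccc1[N+](=O)[O-]` instead bears a formylmethyl group on the ring nitrogen and a 2-nitrophenyl group on the saturated ring carbon, and in this assay compound 2 gives 3630 nM. Of the two numbers measured, compound 2 has the lower one, and its gap to compound 1 lies beyond the usual scatter.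

Compound 3 `O=CCN1N=C(c2ccc3ccccc3c2)CC1/C=C/c1ccccc1` has not yet been measured. It differs from compound 2 in a single place: 2-phenylethenyl in place of 2-nitrophenyl on a saturated ring carbon. Within the data shown here, no step between two measured compounds covers a change of this kind, so there is no measured precedent to lean on. In this assay the step is expected as a 1.5-fold higher number from compound 2 to compound 3 (0.18 log units; within the scatter), a modest move toward a higher number that may not exceed the scatter. Compound 3 is thus expected to give 5500 nM, within a range from 1800 nM to 17000 nM.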

Compound 3, half-maximal inhibitory concentration: 20100 nM
Estimate against measurement, compound 3: 3.7-fold (0.56 log units) below, and the stated range ends below it.
By their numbers in this assay, from the lowest: compound 2; then compounds 1 and 3 (each within the scatter of the next).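

In this assay, the saturated ring carbon next to the ring nitrogen proves sensitive to the group it carries: 2-phenylethenyl in place of 2-nitrophenyl brings a 5.5-fold higher number from compound 2 to compound 3 (0.74 log units; beyond the scatter) with the formylmethyl group and the naphthyl substituent unchanged. Among these compounds, this is the first step here confined to one place, and because it lies beyond the scatter, the two groups are not interchangeable at this position, although each holds one six-membered aromatic ring of carbon only. The 2-nitrophenyl group carries hydrogen-bond acceptors and the 2-phenylethenyl group carries none, but no measurement shown ties the change to that difference or to any other, so its cause remains unexplained.

Still open, on these data alone, is which part of the exchange matters: an amine or a carboxylic acid in place of the nitro group on the phenyl ring, or a saturated 2-phenylethyl chain in place of 2-phenylethenyl, would help to separate the contributions. As far as these compounds go, it is also open whether a step of this size would recur with an acetyl group on the ring nitrogen.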